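Carbamoyl in Place of Trifluoromethyl on a Shared Core

This account rests on a few compounds, and the source may have more. Where it says the series, first, only, none or still open, it means among the compounds named here.

Compound 1 `COc1cccc(-c2ccc3ccc(C)nc3c2)c1` — 860 nM
Compound 2 `Cc1ccc2ccc(-c3cccc(C(F)(F)F)c3)cc2n1` — > 10000 nM

In a functional assay on CHO cells for inhibition of metabotropic glutamate receptor 5 (Rattus norvegicus), read by FLIPR and calcium flux (a lower number here means a stronger inhibitor, a higher number a weaker inhibitor), compound 1 gives 860 nM. Compound 2 reaches only a limit of the assay, > 10000 nM, so no number is known for it (the limit of > 10000 nM in this assay, at which 1 of the 2 values shown sits). Going by the values given here, the single measured step, an at least 11-fold higher number from compound 1 to compound 2 (1.06 log units; beyond the scatter), is a large loss. Compound 3 `Cc1ccc2ccc(-c3cccc(C(N)=O)c3)cc2n1` differs from compound 2 by carbamoyl in place of trifluoromethyl on an aromatic carbon. Among the compounds with values here, no measured step involves a carbamoyl, so this step rests on no precedent; the limit for compound 2 means only a move to a lower number could register. Compound 3 is expected near 6000 nM, within 1000 nM to 30000 nM. The step of an at least 1.6-fold lower number from compound 2 to compound 3 (0.22 log units; that floor lies within the scatter) is therefore an estimate with wide uncertainty.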

Compound 3, half-maximal inhibitory concentration: > 10000 nM
Compound 3 ended at the assay's limit (the forecaster's own chance of this, stated with the estimate: 40%); at least 1.6-fold (0.22 log units) between middle value and limit.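

Carbamoyl in place of methoxy on this aromatic carbon brings an at least 11-fold higher number from compound 1 to compound 3 (1.06 log units; beyond the scatter) in this assay, so a second replacement of methoxy, this one carrying a hydrogen-bond donor, also loses activity. The result for compound 3 is likewise a limit of the assay, so the step between compound 2 and compound 3 cannot be read: the limit of > 10000 nM in this assay, at which 2 of the 3 values shown sit.

On these data alone, how far compound 2 and compound 3 actually differ remains open. So does whether an amine, a hydroxyl or a longer ether chain such as ethoxy at this position would match compound 1.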